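The source may hold more compounds than are shown below. What is called first, only, known or untested is meant among the compounds shown, and "the series" means these compounds.

Compound 2, of structure `CC(C)C(c1ncco1)c1ccc(-c2ccc3cccc(F)c3c2)[nH]c1=O`, is examined in an assay on CHO cells for displacement of a labelled ligand from prostaglandin E2 receptor EP3 subtype (Homo sapiens), read by radioligand binding; on this read-out lower numbers stand for stronger inhibition and higher numbers for weaker inhibition. In this assay compound 2 gives 24 nM. Its only measured companion, compound 1, of structure `CC(C)C(Nc1nnc[nH]1)c1ccc(-c2ccc3cccc(F)c3c2)[nH]c1=O`, gives 22 nM in this assay. Compound 2 carries the highest of the two numbers, and the step between the two is a 1.1-fold higher number from compound 1 to compound 2 (0.04 log units; within the scatter), within the scatter.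

The unmeasured compound 3 has the structure `CC(C)C(Cc1nnc[nH]1)c1ccc(-c2ccc3cccc(F)c3c2)[nH]c1=O`. Its difference from compound 2 is (4H-1,2,4-triazol-3-yl)methyl in place of 1,3-oxazol-2-yl on a saturated chain carbon bound to an aromatic carbon and a saturated chain carbon. Going by the values given here, only one measured step bears on this position, the step from compound 1 to compound 2, in which a (4H-1,2,4-triazol-3-yl)amino group gave way to a 1,3-oxazol-2-yl group at the same saturated chain carbon; that step was a 1.1-fold higher number from compound 1 to compound 2 (0.04 log units; within the scatter) and did not leave the scatter. Compound 3 restores the triazole ring found in compound 1, now joined through a methyl rather than an amino link. Among the compounds with values here, since the one known change at this place produced no step beyond the scatter, compound 3 is expected to show a 1.0-fold higher number from compound 2 to compound 3 (0.02 log units; within the scatter) in this assay, a step of no clear direction. The estimated value of compound 3 is 25 nM, with a range from 10 nM to 65 nM.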

Compound 3, inhibition constant: 10 nM
Compound 3: middle estimate off by 2.5-fold (0.40 log units), on the high side; measured number inside the range.
By their numbers in this assay, from the lowest: compound 3; then compounds 1 and 2 (each within the scatter of the next).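

In this assay, this saturated chain carbon had so far shown only a step within the scatter, but the new result shows that the group it carries can move the number: (4H-1,2,4-triazol-3-yl)methyl in place of 1,3-oxazol-2-yl gives a 2.4-fold lower number from compound 2 to compound 3 (0.38 log units; beyond the scatter). The link also counts, not only the ring, since keeping the triazole and changing (4H-1,2,4-triazol-3-yl)amino to (4H-1,2,4-triazol-3-yl)methyl gives a 2.2-fold lower number from compound 1 to compound 3 (0.34 log units; beyond the scatter), a modest step of about the same size. No evidence at hand gives a reason for either step.

From the compounds shown here alone, what remains open is whether the lower number needs the triazole ring at all, as a 1,3-oxazol-2-yl group carried on the same methyl link would separate the contribution of the ring from that of the link. Also open, going by these compounds, is how far this position tolerates other groups, such as a longer chain, for instance an ethyl link to the triazole, or a carboxylic acid or a simple amine in place of the ring.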